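A few compounds are considered here, and "the series" means these few. Any claim that something is new, unique, unknown or untested is made for them only; others in the source may bear on it.

Of the compounds shown here, three have so far been tested in an ADME assay on the whole organism with Oryza sativa as the target, tested at 0.1 uM; on this read-out higher numbers stand for a weaker effect at the one concentration tested and lower numbers for a stronger effect. Compound 1 `Cc1ccc(NC(=O)N[C@H](C)c2ccccc2)cc1` gives 100% in this assay. Compound 2 `Cc1ccc(NC(=O)N[C@@H](C)c2ccccc2)cc1` gives 100%. Compound 3 `CC(=O)c1ccccc1NC(=O)N[C@@H](C)c1ccccc1`, which carries a different group on its aromatic ring, gives 100%.

For the measured compounds named here, the only single-change step measured is no change at the digits printed from compound 1 to compound 2 (within the scatter); given (the fact that compounds 1 and 2 differ only in the configuration as drawn), reversing the drawn configuration at the saturated chain carbon leaves the reading where it was. Compound 2 therefore sits level with compounds 1 and 3 at the digits shown, with no change beyond the scatter towards either.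

Compound 4 `C[C@H](NC(=O)Nc1ccc(I)cc1)c1ccccc1` has not yet been tested. Relative to compound 2 the change is iodo in place of methyl on an aromatic carbon: one heavy atom leaves and one heavy atom enters on an aromatic carbon of a six-membered aromatic ring of carbon only, with no donors, acceptors or charge involved.

Going by the values given here, no measured step exchanges one aromatic substituent for another, so the step from compound 1 to compound 2 bears only loosely on this swap. What the data do show is that compounds 1, 2 and 3, a different aromatic group included, all sit at the same reading in this assay. The step of no change at the digits printed from compound 2 to compound 4 (within the scatter) is therefore expected to be nothing beyond the scatter. Compound 4 is estimated to give 100% in this assay, within a range from 85% to 100%.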

Compound 4, a percentage reported as activity, at one concentration (the size of the read-out at that concentration, not a potency): 99%
Compound 4: the middle estimate sits 1 percentage points above what was measured; the measured number falls inside the stated range.
By their numbers in this assay, from the lowest: compounds 4, 1, 2 and 3 (each within the scatter of the next).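

Iodo in place of methyl on an aromatic carbon, para to a large group, gives a number 1 percentage points lower from compound 2 to compound 4 (within the scatter) in this assay. For the compounds shown here, the earlier single-change step altered only the drawn configuration at the saturated chain carbon, so this is the first single change measured on the aromatic ring, and at this place the reading does not separate methyl from iodo, at the one concentration tested. Nothing at hand accounts for this result, as the only available fact concerns the configuration of compounds 1 and 2 and does not touch a change of aromatic group.

Methyl and iodo both enter as one heavy atom with no hydrogen-bond donors or acceptors and no net charge, so it remains open whether an amine, a carboxylic acid or a longer chain at this same aromatic carbon would also leave the reading in place. Going by these compounds, it also remains open whether a group on the saturated chain carbon other than methyl, such as ethyl, would shift the reading in this assay.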